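This account rests on a few compounds, and the source may have more. Where it says the series, first, only, none or still open, it means among the compounds named here.

Compound 1 `Nc1nc(OCc2ccccc2)c2[nH]c(O)nc2n1` and compound 2 `Nc1nc(OCc2ccccc2)c2[nH]c(Br)nc2n1` share one core and were compared in an assay on HT-29 cells with Methylated-DNA--protein-cysteine methyltransferase (Homo sapiens) as the target, with a stated time of 4 h; a lower number here means that less compound is needed, a higher number that more compound is needed for the effect. Compound 1 gives 0.15 uM there, the higher of the two numbers recorded; compound 2 gives 0.06 uM. Going by the values given here, the one measured step, a 2.5-fold lower number from compound 1 to compound 2 (0.40 log units; beyond the scatter), came from a bromo in place of hydroxy on an aromatic carbon.

Compound 3 `Oc1nc(OCc2ccccc2)c2[nH]c(O)nc2n1` is not yet measured. Relative to compound 1 it shows hydroxy in place of amino on an aromatic carbon. Among the compounds with values here, neither measured compound varies this group, so no measured step speaks directly to this change; the step from compound 1 to compound 2 concerns a different position and serves only to show the scale on which the core responds.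

With nothing to anchor the change, compound 3 is estimated to give a somewhat higher number in this assay than compound 1, a step of a 4.0-fold higher number from compound 1 to compound 3 (0.60 log units; beyond the scatter), around 0.6 uM, expected to lie between 0.15 uM and 3 uM.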

Compound 3, concentration for half-maximal effect: 45 uM
For compound 3 the middle estimate is 75-fold (1.88 log units) below the measured one, and the stated range ends below it.
By their numbers in this assay, from the lowest: compound 2; then compound 1; then compound 3.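

In this assay, going by these compounds alone, the position between two ring nitrogen atoms proves far more sensitive than the earlier compounds could show: hydroxy in place of amino gives a 300-fold higher number from compound 1 to compound 3 (2.48 log units; beyond the scatter), a much larger change than a 2.5-fold lower number from compound 1 to compound 2 (0.40 log units; beyond the scatter) at the other varied position. Amino and hydroxy have the same counts of heavy atoms, hydrogen-bond donors and acceptors, and the same net charge, so these counts do not separate the two groups, although the numbers differ sharply. Nothing available here accounts for the size of this step.

The compounds shown leave open whether a methylamino group, a dimethylamino group or a plain hydrogen here would stay close to compound 1 or move towards compound 3. They also leave open whether the bromo group of compound 2 would change the size of this step.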